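The source may hold more compounds than are shown below. What is called first, only, known or untested is meant among the compounds shown, and "the series" means these compounds.

Within the data shown here, compound 1 `Nc1ccccc1NC(=O)c1ccc(CSC(=S)N2CCN(C3CCCCC3)CC2)cc1` gives 89.9% in a functional assay on A-375 cells (Homo sapiens) for antiproliferative activity, read by CCK-8 assay, with a stated time of 72 h, tested at 8 uM (a higher number here means a stronger effect of the compound at the concentration tested, a lower number a weaker effect), the largest of the three numbers so far, although its gaps to compound 3 `CN(Cc1ccncc1)C(=S)SCc1ccc(C(=O)Nc2ccccc2N)cc1` with 86.1% and to compound 2 `CC1CCCCN1C(=S)SCc1ccc(C(=O)Nc2ccccc2N)cc1` with 85.2% both lie within the usual scatter. Among the measured compounds shown here, the single measured step, a number 0.9 percentage points higher from compound 2 to compound 3 (within the scatter), changes the group on the thiocarbonyl carbon, not the ring nitrogen.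

Compound 4 `Nc1ccccc1NC(=O)c1ccc(CSC(=S)N2CCN(c3cccnc3)CC2)cc1` differs from compound 1 by pyridin-3-yl in place of cyclohexyl on an amine nitrogen in a ring. For the measured compounds named here, no measured step addresses this position; the only variation seen, at the thiocarbonyl carbon, produced nothing beyond the scatter, so the expected step of a number 4.9 percentage points lower from compound 1 to compound 4 (within the scatter) is likewise within the scatter. For compound 4 the estimate in this assay is 85%, ranging from 70% to 95%.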

Compound 4, a percentage reported as inhibition, at one concentration (the size of the read-out at that concentration, not a potency): 88.8%
Compound 4: the middle estimate sits 3.8 percentage points below what was measured; the range from low to high includes it.
By their numbers in this assay, from the lowest: compounds 2, 3, 4 and 1 (each within the scatter of the next).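

In this assay, among these compounds, the only step at the amine nitrogen in the ring, pyridin-3-yl in place of cyclohexyl, gives a number 1.1 percentage points lower from compound 1 to compound 4 (within the scatter) and so does not separate the two groups. At this position, a non-aromatic carbon ring and an aromatic ring with a hydrogen-bond acceptor give read-outs within the scatter of each other. No measurement shown offers a reason for this result.

As far as these compounds go, whether a methyl group, a carboxylic acid or a longer chain bearing an amine on this nitrogen would keep the read-out remains open. A single concentration also leaves any difference in potency between these compounds unresolved.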